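The source may hold more compounds than are shown below. What is called first, only, known or untested is meant among the compounds shown, and "the series" means these compounds.

Compound 1 `CNC(=O)[C@@]12C[C@@H]1[C@@H](n1cnc3c(N)nc(C#Cc4ccccc4)nc31)[C@H](O)[C@@H]2O` gives 1.51 nM in an assay on CHO cells for displacement of a labelled ligand from adenosine receptor A3 (Homo sapiens), read by scintillation counting, with a stated time of 60 min; on this read-out lower numbers stand for stronger inhibition and higher numbers for weaker inhibition; compound 2 `CNC(=O)[C@@]12C[C@@H]1[C@@H](n1cnc3c(NC4CC4c4cccc(F)c4)nc(C#Cc4ccccc4)nc31)[C@H](O)[C@@H]2O` gives 16.5 nM.

Among the measured compounds shown here, on these two numbers compound 2 stands highest, its only neighbour being compound 1, with an 11-fold higher number from compound 1 to compound 2 (1.04 log units; beyond the scatter) separating them. Compound 3 `CNC(=O)[C@@]12C[C@@H]1[C@@H](n1cnc3c(NC4CC4c4cccc(Cl)c4)nc(C#Cc4ccccc4)nc31)[C@H](O)[C@@H]2O` differs from compound 2 by chloro in place of fluoro on an aromatic carbon. For the measured compounds named here, no measured step bears on this change directly; the one step seen concerns a different place and a much larger group, so it gives no guide to a halogen swap of this kind. The step of a 1.1-fold lower number from compound 2 to compound 3 (0.04 log units; within the scatter) is therefore expected to stay within the scatter. Compound 3 is estimated at 15 nM, with a range from 6 nM to 40 nM.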

Compound 3, inhibition constant: 11.2 nM
The estimate for compound 3 lay 1.3-fold (0.13 log units) above the measured number; the measured number falls inside the stated range.
By their numbers in this assay, from the lowest: compound 1; then compounds 3 and 2 (each within the scatter of the next).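

In this assay the halogen on this aromatic carbon can be exchanged with little consequence, with a 1.5-fold lower number from compound 2 to compound 3 (0.17 log units; within the scatter) for chloro in place of fluoro. The higher number is not particular to fluoro, since the chloro side group also stands beyond the scatter, with a 7.4-fold higher number from compound 1 to compound 3 (0.87 log units; beyond the scatter) on the nitrogen. Nothing available gives a reason for either step.

On these data alone, whether a methoxy group, a nitrile or plain hydrogen at this ring carbon would stay close to these two compounds remains open. So does whether a smaller methyl group on the nitrogen would give a smaller step.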